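The source may hold more compounds than are shown below. What is called first, only, known or untested is meant among the compounds shown, and "the series" means these compounds.

In an assay for inhibition of Fatty-acid amide hydrolase 1 (Rattus norvegicus), using a Dixon plot (on this read-out lower numbers stand for stronger inhibition and higher numbers for weaker inhibition), compound 1, `O=Cc1ccc(-c2cnc(C(=O)CCCCCCc3ccccc3)o2)nc1`, gives 2.2 nM, and compound 2, `O=C(CCCCCCc1ccccc1)c1ncc(-c2ccc(CO)cn2)o1`, gives 3.2 nM; the two are linked by a 1.5-fold higher number from compound 1 to compound 2 (0.16 log units; within the scatter). Compound 3, `O=CCCCCc1cnc(C(=O)CCCCCCc2ccccc2)o1`, gives 14.6 nM, which is the highest of the three numbers: it is separated from compound 2 by a 4.6-fold higher number from compound 2 to compound 3 (0.66 log units; beyond the scatter) and from compound 1 by a 6.6-fold higher number from compound 1 to compound 3 (0.82 log units; beyond the scatter), so within this small set compound 3 stands as the weakest inhibitor.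

Compound 4, `O=C(CCCCCCc1ccccc1)c1ncc(CCCCCBr)o1`, keeps the saturated chain of compound 3 and changes only its end: bromomethyl in place of formyl on a saturated chain carbon, four bonds along the chain from an aromatic carbon. Among the compounds with values here, none of the measured steps alters exactly this position. The nearest analogy is the step from compound 1 to compound 2, where the formyl group was exchanged for hydroxymethyl on an aromatic carbon and the number moved only within the scatter. The larger steps into compound 3 concern the exchange of the ring-bearing group for the chain, not the terminal group, so they say little about compound 4. On this basis the step is expected to be small, without a firm direction: a 1.0-fold higher number from compound 3 to compound 4 (0.01 log units; within the scatter) is the expectation for compound 4. The value of compound 4 in this assay is therefore estimated at 15 nM, with a range from 5 nM to 45 nM.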

Compound 4, inhibition constant: 6.1 nM
Beside the measured number, compound 4's estimate is 2.5-fold (0.39 log units) above it, within the range that was stated.
By their numbers in this assay, from the lowest: compounds 1, 2 and 4 (each within the scatter of the next, the first and the last beyond it); then compound 3.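

In this assay, within the data shown here, the end of the saturated chain turns out to matter: bromomethyl in place of formyl, four bonds along the chain from an aromatic carbon, gives a 2.4-fold lower number from compound 3 to compound 4 (0.38 log units; beyond the scatter), whereas the only earlier change of a formyl group, made on an aromatic carbon, gave a 1.5-fold higher number from compound 1 to compound 2 (0.16 log units; within the scatter). The bromine-ended chain also changes how the chain compares with the ring-bearing groups, since 5-bromopentyl in place of 5-(hydroxymethyl)pyridin-2-yl gives a 1.9-fold higher number from compound 2 to compound 4 (0.28 log units; within the scatter), and replacing the ring-bearing group of compound 1 gives a 2.8-fold higher number from compound 1 to compound 4 (0.44 log units; beyond the scatter), so the distance seen with the formyl-ended chain of compound 3 is not a fixed cost of having a chain on that aromatic carbon. No measurement offered here accounts for the shift.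

Going by these compounds, a single pair cannot separate the loss of the formyl group from the gain of the bromine, so it remains open whether any other end on this chain, such as a chlorine atom, a hydroxyl group, a carboxylic acid or an amine, would behave like either one. Also open, on these data alone, is how a shorter or longer chain carrying the same bromine would compare with compound 4.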